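Aryl thioether on the shared core: expected gain in affinity

This account rests on a few compounds, and the source may have more. Where it says the series, first, only, none or still open, it means among the compounds named here.

Measured so far:
compound 1 `Nc1nc(SCc2ccc(Br)cc2)c2ncn([C@@H]3O[C@H](CO)[C@@H](O)[C@H]3O)c2n1`: 813 nM
compound 2 `Nc1nc(SI)c2ncn([C@@H]3O[C@H](CO)[C@@H](O)[C@H]3O)c2n1`: 81300 nM
compound 3 `CC(C)Sc1nc(N)nc2c1ncn2[C@@H]1O[C@H](CO)[C@@H](O)[C@H]1O`: 191000 nM

In an assay on isolated protein for binding affinity to Equilibrative nucleoside transporter 1 (Homo sapiens) (on this read-out higher numbers stand for weaker inhibition and lower numbers for stronger inhibition), compound 3 gives the highest of the three numbers. Its nearest neighbour is compound 2, as a 2.3-fold higher number from compound 2 to compound 3 (0.37 log units; beyond the scatter) shows, and its furthest is compound 1, as a 230-fold higher number from compound 1 to compound 3 (2.37 log units; beyond the scatter) shows. Compound 4 `CC(=O)c1cc(Cl)ccc1Sc1nc(N)nc2c1ncn2[C@@H]1O[C@H](CO)[C@@H](O)[C@H]1O` differs from compound 3 by 2-acetyl-4-chlorophenyl in place of isopropyl on a sulfur. Going by the values given here, the step that bears on this is the one from compound 1 to compound 3, where a 4-bromobenzyl group on the sulfur in place of an isopropyl gave the much lower number; compound 4 likewise carries an aromatic ring on that sulfur, though bound directly and differently substituted. A large fall in the number is therefore expected, a 64-fold lower number from compound 3 to compound 4 (1.80 log units; beyond the scatter), short of the full return. Compound 4 is estimated at 3000 nM, within 500 nM to 20000 nM.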

Compound 4, half-maximal inhibitory concentration: 14500 nM
Compound 4: middle estimate off by 4.8-fold (0.68 log units), on the low side; low and high end bracket the measured number.
By their numbers in this assay, from the lowest: compound 1; then compound 4; then compound 2; then compound 3.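

With a 13-fold lower number from compound 3 to compound 4 (1.12 log units; beyond the scatter) and with a 5.6-fold lower number from compound 2 to compound 4 (0.75 log units; beyond the scatter) an aromatic ring bound directly to the sulfur is shown to lower the number too, so the fall does not depend on the 4-bromobenzyl group alone. Yet an 18-fold higher number from compound 1 to compound 4 (1.25 log units; beyond the scatter) leaves 2-acetyl-4-chlorophenyl well short of 4-bromobenzyl on this sulfur. Nothing available explains these differences.

Going by these compounds, whether the gap to compound 1 follows from the carbon link of the benzyl group or from the acetyl and chloro groups stays open. On these data alone, how a plain phenyl or a plain benzyl on the sulfur would read is also open.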